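A few compounds are considered here, and "the series" means these few. Any claim that something is new, unique, unknown or untested is made for them only; others in the source may bear on it.

Measured in an assay for binding affinity, read by spectrophotometry; a lower number here means a stronger inhibitor, a higher number a weaker inhibitor:

Compound 1 `C[C@H](CCCN1CCCC1)Nc1ccnc2cc(Cl)ccc12`: 140000 nM
Compound 2 `C[C@@H](CCCN1CCCC1)Nc1ccnc2cc(Cl)ccc12`: 180000 nM
Compound 3 `C[C@@H](CCCN(C)C)Nc1ccnc2cc(Cl)ccc12`: 150000 nM

Compound 1 gives the lowest of these three numbers, yet compound 2 and compound 3 both sit within the scatter of it, so the three cannot be told apart. Compounds 1 and 2 differ only in configuration as drawn (the fact that compounds 1 and 2 differ only in the configuration as drawn), and a 1.3-fold higher number from compound 1 to compound 2 (0.11 log units; within the scatter). Replacing the ring amine at the chain end by an open-chain amine changed little as well: a 1.2-fold lower number from compound 2 to compound 3 (0.08 log units; within the scatter).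

Compound 4 `CCN(C)CCC[C@@H](C)Nc1ccnc2cc(Cl)ccc12` has not yet been measured. It differs from compound 1 by ethyl(methyl)amino in place of pyrrolidin-1-yl on a saturated chain carbon, four bonds along the chain from a nitrogen on an aromatic ring. Among the compounds with values here, the step from compound 2 to compound 3 is the nearest precedent: the same ring amine gave way to an open-chain amine at the same place, and the number stayed within the scatter. On that basis the expected step is no change at the digits printed from compound 1 to compound 4 (within the scatter), with no change beyond the scatter in either direction. Compound 4 is therefore expected to give about 140000 nM in this assay, within a range from 70000 nM to 280000 nM.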

Compound 4, half-maximal inhibitory concentration: 140000 nM
Compound 4: the middle estimate sits on the measured number at the digits printed, within the range that was stated.
By their numbers in this assay, from the lowest: compounds 1, 4, 3 and 2 (each within the scatter of the next).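

Swapping pyrrolidin-1-yl for ethyl(methyl)amino at this place left the number flat in this assay (no change at the digits printed from compound 1 to compound 4 (within the scatter)). Within the data shown here, until now, a change from a ring amine to an open-chain amine at this chain end had been seen only in the configuration drawn for compound 2, with dimethylamino as the open-chain group. This step shows the same flat outcome in the configuration drawn for compound 1 and with a second open-chain amine, although nothing given here explains why the number holds steady.

All four compounds carry an amine at the chain end, and all differ only within a narrow set of small amines. As far as these compounds go, it remains open whether a carboxylic acid at that end, or a longer chain leading to the amine, would move the number beyond the scatter.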